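The source may report more compounds than this note shows. Statements on the series, on what has been measured and on what is new or still open speak of the compounds shown alone.

Working notes on the series. The read-out followed here is a physicochemical assay for solubility, in phosphate buffer, measured as thermodynamic solubility, at pH 2; on this read-out lower numbers stand for lower solubility and higher numbers for higher solubility. Compound 1 `CC(=O)NC1CCN(c2nc3c(c(Nc4ccc(C(F)(F)F)cc4)n2)CCN(c2ncccc2C(F)(F)F)CC3)C1` gives 202 ug/mL in this assay. Compound 2 `CCC(CC)N1CCN(c2nc3c(c(Nc4ccc(C(F)(F)F)cc4)n2)CCN(c2ncccc2C(F)(F)F)CC3)CC1` gives 243 ug/mL. Compound 3 `CN1CCCCC1CNc1nc2c(c(Nc3ccc(C(F)(F)F)cc3)n1)CCN(c1ncccc1C(F)(F)F)CC2` is reported in this assay only as a limit of the assay, > 277 ug/mL; (the limit of > 277 ug/mL in this assay, at which 1 of the 3 values shown sits). The two steps toward compound 3 read an at least 1.3-fold higher number from compound 1 to compound 3 (0.13 log units; that floor lies within the scatter) and an at least 1.1-fold higher number from compound 2 to compound 3 (0.05 log units; that floor lies within the scatter), each a floor that lies within the scatter, and a 1.2-fold higher number from compound 1 to compound 2 (0.08 log units; within the scatter) is within the scatter as well. Compound 3 therefore stands where all three measured compounds overlap, at the upper edge of what the assay reports.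

Compound 4 `FC(F)(F)c1ccc(Nc2nc(NC3CCCNC3)nc3c2CCN(c2ncccc2C(F)(F)F)CC3)cc1` differs from compound 3 by piperidin-3-yl in place of (1-methylpiperidin-2-yl)methyl on a nitrogen on an aromatic ring. For the measured compounds named here, the measured steps that touch the changed position are the two leading into compound 3, both floors within the scatter, and neither of them involves piperidin-3-yl; no measured pair shows how that group behaves in this assay. In this assay the step is expected to be a step that the limit leaves unreadable from compound 3 to compound 4, nothing beyond the scatter. Compound 4 is thus expected to give about 300 ug/mL, within 150 ug/mL to 600 ug/mL, and a further limit of the assay rather than a number is the more likely outcome.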

Compound 4, solubility: > 235 ug/mL
Compound 4: no number, only a limit (the forecaster's own chance of this, stated with the estimate: 60%); the middle value is on the limit's open side.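

In this assay compound 4 is reported only as a limit: the limit of > 235 ug/mL in this assay, at which 1 of the 4 values shown sits. For the compounds shown here, the one readable step is an at least 1.1-fold higher number from compound 1 to compound 4 (0.06 log units; that floor lies within the scatter), a floor within the scatter, so (piperidin-3-yl)amino in place of 3-acetamidopyrrolidin-1-yl on an aromatic carbon shows no change that can be told from the scatter, and the steps linking compound 4 to compound 2 and to compound 3 cannot be read. This position now carries a second group that ends in a limit, and the swap of (1-methylpiperidin-2-yl)methyl, with 0 hydrogen-bond donors, for piperidin-3-yl, with 1 hydrogen-bond donor, has no size that can be stated in this read-out.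

The compounds shown leave open how compound 3 and compound 4 stand relative to each other, and whether the loss of the methyl group or the shift from a (1-methylpiperidin-2-yl)methyl chain to a directly attached ring matters at all. Also open, on these data alone, is whether a different group on this nitrogen, such as a morpholine or a carboxylic acid on a longer chain, would give a true number in this assay rather than another limit.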